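Removing One Fluorine from Compound 2

This account rests on a few compounds, and the source may have more. Where it says the series, first, only, none or still open, it means among the compounds named here.

Of the compounds shown here, three have been measured in a functional assay on MCF7 cells (Homo sapiens) for cytotoxicity, read by MTT assay, with a stated time of 72 h; on this read-out higher numbers stand for weaker inhibition of growth and lower numbers for stronger inhibition of growth. Compound 1 `CC(C)COC(=O)Nc1ccc([Se][Se]c2ccc(NC(=O)OCC(C)C)cc2)cc1` gives 19000 nM, and compound 3 `CCCCOC(=O)Nc1ccc([Se][Se]c2ccc(NC(=O)OCCCC)cc2)cc1` gives 17300 nM. Compound 2 `N#C[Se]c1ccc(NC(=O)Oc2ccc(F)cc2)cc1` gives 8300 nM, the lowest of the three numbers; its gap to compound 3 and its gap to compound 1 both lie beyond the usual scatter, so compound 2 is the strongest inhibitor of growth among the three. Compound 4 `N#C[Se]c1ccc(NC(=O)Oc2ccccc2)cc1` has not yet been measured. It differs from compound 2 in one place: hydrogen in place of fluoro on an aromatic carbon. Among the compounds with values here, no pair of measured compounds differing in one place is available, so there is no measured step to lean on. For so small a change the step is expected to be a 1.1-fold higher number from compound 2 to compound 4 (0.04 log units; within the scatter), with no direction beyond the scatter. Compound 4 is therefore estimated at 9000 nM in this assay, within a range from 4500 nM to 18000 nM.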

Compound 4, concentration for 50% growth inhibition in the MCF7 assay: 4000 nM
Compound 4: the middle estimate sits 2.3-fold (0.35 log units) above what was measured; the whole stated range lies above it.
By their numbers in the MCF7 assay, from the lowest: compound 4; then compound 2; then compounds 3 and 1 (each within the scatter of the next).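

Within the data shown here, in the MCF7 assay, hydrogen in place of fluoro on this aromatic carbon gives a 2.1-fold lower number from compound 2 to compound 4 (0.32 log units; beyond the scatter), the first measured step, so even this small change at this position can shift growth inhibition, and fluoro is not needed there for it. In a physicochemical assay, with a stated time of 6 min, tested at 0.1 mg/mL (a lower number here means less inhibition, a higher number more inhibition at the concentration tested (going by the name of the read-out)), compound 2 gives > 25%, which is a limit of the assay. In the physicochemical assay compound 4 gives > 25%, also a limit, so the step here cannot be read, with both values at one limit: the limit of > 25% in the physicochemical assay, at which 2 of the 2 values shown sit.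

Still open, as far as these compounds go, is whether a chlorine, a methoxy group or an amine on this carbon would lower the number further or raise it again.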